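Half-life of an oxadiazole series in liver microsomes

The source may report more compounds than this note shows. Statements on the series, on what has been measured and on what is new or still open speak of the compounds shown alone.

Measured compounds:
compound 1, `NS(=O)(=O)c1cc(-c2nnc(CN3CCN(Cc4ccccc4)CC3)o2)c(Cl)cc1SCc1ccccc1`, 0.08 h
compound 2, `NC(=O)c1cn(Cc2nnc(-c3cc(S(N)(=O)=O)c(SCc4ccccc4)cc3Cl)o2)nn1`, 0.435 h

The account concerns two measured compounds and one that is still to be measured. In an ADME assay on microsomes from liver (Homo sapiens) for metabolic stability, read by LC-MS, using NADPH, tested at 5 uM (a lower number here means that the compound disappears faster, a higher number that the compound lasts longer), compound 1 gives 0.08 h. Compound 2 stands highest of the two numbers; its nearest neighbour is compound 1, whose number is lower by an amount that lies beyond the usual scatter of such measurements, so the two compounds differ in this assay.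

Compound 3, `NS(=O)(=O)c1cc(-c2nnc(/C=C/c3cccc(Cl)c3)o2)c(Cl)cc1SCc1ccccc1`, has not yet been measured. It differs from compound 2 by 2-(3-chlorophenyl)ethenyl in place of (4-carbamoyl-1H-1,2,3-triazol-1-yl)methyl on an aromatic carbon.

Among the compounds with values here, no step between two measured compounds resembles this change, so nothing in the data fixes its size. Compound 3 is expected to sit below compound 2, with a step of a 2.2-fold lower number from compound 2 to compound 3 (0.34 log units; beyond the scatter) that would be beyond the scatter. The estimate for compound 3 in this assay is 0.2 h, between 0.07 h and 0.6 h.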

Compound 3, half-life: 0.352 h
Compound 3: the middle estimate sits 1.8-fold (0.25 log units) below what was measured; the range from low to high includes it.
By their numbers in this assay, from the lowest: compound 1; then compounds 3 and 2 (each within the scatter of the next).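

With 2-(3-chlorophenyl)ethenyl in place of (4-carbamoyl-1H-1,2,3-triazol-1-yl)methyl on this aromatic carbon of the five-membered ring, this assay gives a 1.2-fold lower number from compound 2 to compound 3 (0.09 log units; within the scatter). Within the data shown here, this is the first step read between two measured compounds here, and it shows that a group with 1 hydrogen-bond donor and 4 hydrogen-bond acceptors and a group with 0 of either, both of 9 heavy atoms, give half-lives that this measurement cannot tell apart at this position. No measurement at hand accounts for this result.

As far as these compounds go, what remains open is whether a carboxylic acid in place of the carbamoyl of compound 2 would leave the half-life within the scatter. From the compounds shown here alone, it is equally open whether a longer chain in place of the ethenyl of compound 3, or a simple amine at this position, would do so.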